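Two Low-Efficacy Agonists and a Pyridyl Acid Variant

The source may hold more compounds than are shown below. What is called first, only, known or untested is meant among the compounds shown, and "the series" means these compounds.

compound 1 `O=C(O)Cc1ccc(NC(=O)C(C2CCCCC2)n2c(-c3ccc(Cl)cc3)nc3cc(F)c(F)cc32)cc1`: 14%
compound 2 `O=C(O)CO[C@H]1CC[C@H](NC(=O)[C@H](C2CCCCC2)n2c(-c3ccc(Cl)nc3)nc3cc(F)c(F)cc32)CC1`: 26%

In a functional assay for agonist activity at Bile acid receptor (Homo sapiens), read by a luciferase reporter (a higher number here means a larger maximal response, a lower number a smaller maximal response), compound 1 gives 14%, the lower of the two numbers shown, while compound 2 gives 26%, a gap that lies beyond the usual scatter. Compound 3 `O=C(O)c1ccc(NC(=O)C(C2CCCCC2)n2c(-c3ccc(Cl)cc3)nc3cc(F)c(F)cc32)nc1` has not yet been measured. It differs from compound 1 in one place: 5-carboxypyridin-2-yl in place of 4-(carboxymethyl)phenyl on an amide-type nitrogen. Going by the values given here, no measured pair shows this change, so only a modest step is expected, in either direction and not clearly beyond the scatter. Compound 3 is expected to give 18%, between 6% and 34%, so that the estimated step of a number 4 percentage points higher from compound 1 to compound 3 (within the scatter) stays small.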

Compound 3, largest response reached (reported as efficacy), in percent of the reference or control that the assay uses: 20%
Beside the measured number, compound 3's estimate is 2 percentage points below it, within the range that was stated.
By their numbers in this assay, from the lowest: compounds 1, 3 and 2 (each within the scatter of the next, the first and the last beyond it).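

In this assay, 5-carboxypyridin-2-yl in place of 4-(carboxymethyl)phenyl on the amide-type nitrogen gives a number 6 percentage points higher from compound 1 to compound 3 (within the scatter). This position therefore accepts a ring with one hetero atom and the loss of one heavy atom from the group with no change that the read-out can separate from scatter. Nothing available explains this outcome.

Going by these compounds alone, the single change swaps the ring and shortens the acid group together, so the two remain unseparated. From the compounds shown here alone, how a tetrazole or an amine would read in place of the carboxylic acid at this position also remains open.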